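The source may hold more compounds than are shown below. What is called first, only, known or untested is meant among the compounds shown, and "the series" means these compounds.

Working notes on the series in a functional assay on SK-MEL-2 cells (Homo sapiens) for inhibition, read by sulforhodamine B assay, with a stated time of 48 h; on this read-out lower numbers stand for stronger inhibition of growth and higher numbers for weaker inhibition of growth. Compound 2 `COc1cc(-c2cc(/C=C/C(=O)c3ccc(N)cc3)[nH]n2)cc(OC)c1OC` gives 2850 nM and holds the lowest of the two numbers recorded; compound 3 `COc1ccc(C(=O)/C=C/c2cc(-c3cc(OC)c(OC)c(OC)c3)n[nH]2)cc1` gives 4140 nM, the step of a 1.5-fold higher number from compound 2 to compound 3 (0.16 log units; within the scatter) lying within the scatter. For compound 1 `COc1ccc(-c2cc(/C=C/C(=O)c3ccc(N)cc3)[nH]n2)cc1` the result is "not determined" (no result reported) in this assay. Compound 4 `COc1ccc(-c2cc(/C=C/C(=O)c3ccc(N)cc3)[nH]n2)cc1OC` differs from compound 2 by hydrogen in place of methoxy on an aromatic carbon. Going by the values given here, the single measured step, from compound 2 to compound 3, concerns the amino-bearing ring of the ketone side and does not bear on this change; no measured step touches the ring carrying the methoxy groups. The expected step in this assay is therefore a 1.4-fold higher number from compound 2 to compound 4 (0.15 log units; within the scatter), of uncertain direction and not clearly beyond the scatter. Compound 4 is estimated at 4000 nM, with a range from 1500 nM to 12000 nM.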

Compound 4, concentration for 50% growth inhibition: 8440 nM
Compound 4: the middle estimate sits 2.1-fold (0.32 log units) below what was measured, and the stated range covers the measured number.
By their numbers in this assay, from the lowest: compounds 2 and 3 (each within the scatter of the next); then compound 4.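

Hydrogen in place of methoxy gives a 3.0-fold higher number from compound 2 to compound 4 (0.47 log units; beyond the scatter), the first step in the series to lie beyond the scatter and the first to reach the ring carrying the methoxy groups. The methoxy ortho to a methoxy group and meta to a large group therefore goes with the lower number, though the step is modest. Nothing available accounts for this step.

Steps to compound 1 cannot be read, so the other methoxy positions stay unresolved. From the compounds shown here alone, whether ethoxy or hydroxy at this position would keep the lower number remains open.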